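A few compounds are considered here, and "the series" means these few. Any claim that something is new, unique, unknown or untested is made for them only; others in the source may bear on it.

Measured in a functional assay on PC-3 cells (Homo sapiens) for cytotoxicity, read by colorimetric assay and MTT assay; a lower number here means a stronger inhibitor, a higher number a weaker inhibitor:

- compound 1 `COc1ccc2cc(-c3ccccc3)c(O)nc2c1`: 10000 nM
- compound 2 `COc1cc(OC)c2cc(-c3ccc(OCc4ccccc4)cc3)c(O)nc2c1`: 10000 nM
- compound 3 `CCN(CC)C(=O)Cn1c(=O)c(-c2ccc(OC)cc2)cc2c(OC)cc(OC)cc21`: 10000 nM

Compound 3 at 10000 nM stands level with the other two, and nothing separates the three on these numbers. The next structure is compound 4 `COC(=O)CCn1c(=O)c(-c2ccc(OC)cc2)cc2c(OC)cc(OC)cc21`, which carries (methoxycarbonyl)methyl in place of diethylcarbamoyl on a saturated chain carbon bound to an aromatic nitrogen. Cut one bond further out, the same difference reads (diethylcarbamoyl)methyl to 2-(methoxycarbonyl)ethyl.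

For the measured compounds named here, no measured pair differs in one place only, so the data give no direct guide to the size of this change. The only basis is the flat reading in this assay, where compound 1 gives 10000 nM, compound 2 gives 10000 nM and compound 3 gives 10000 nM. No step beyond the scatter is expected in this assay. The expected step is no change at the digits printed from compound 3 to compound 4 (within the scatter). For compound 4 the estimated value is 10000 nM, with an expected range of 4000 nM to 20000 nM.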

Compound 4, half-maximal inhibitory concentration: 10000 nM
Compound 4: middle estimate and measured number agree at the digits printed, within the range that was stated.
By their numbers in this assay, from the lowest: compounds 1, 2, 3 and 4 (each within the scatter of the next).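

In this assay, putting (methoxycarbonyl)methyl in place of diethylcarbamoyl on a saturated chain carbon bound to an aromatic nitrogen gives no change at the digits printed from compound 3 to compound 4 (within the scatter). For the compounds shown here, this is the first comparison that isolates one place, and it shows that this exchange of chain end, from an amide-type group to a methyl ester, does not separate the two compounds in this read-out. Nothing at hand bears on why the step is flat.

Because both compounds sit at the same printed value, the pair cannot show whether this position can influence the reading at all. A free carboxylic acid or a dimethylamino group at the chain end, or a longer chain, would test whether any change here moves the value in this assay.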